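Pyrimidin-2-yl Replaces 4-Methylphenyl in an Antiproliferative Series

The source may hold more compounds than are shown below. What is called first, only, known or untested is meant among the compounds shown, and "the series" means these compounds.

Three compounds share one core and differ only in the group on an amine nitrogen in a ring. In a functional assay on A-375 cells (Homo sapiens) for antiproliferative activity, read by CCK-8 assay, with a stated time of 72 h, tested at 8 uM (a higher number here means a stronger effect of the compound at the concentration tested, a lower number a weaker effect), compound 1 `Nc1ccccc1NC(=O)c1ccc(CSC(=S)N2CCN(Cc3ccccn3)CC2)cc1` gives 82.4%. Compound 2 `COc1ccc(N2CCN(C(=S)SCc3ccc(C(=O)Nc4ccccc4N)cc3)CC2)cc1` gives 35.9% in this assay, and compound 3 `Cc1ccc(N2CCN(C(=S)SCc3ccc(C(=O)Nc4ccccc4N)cc3)CC2)cc1` gives 26.4%. Compound 3 holds the lowest of the three numbers; its gap to compound 2, a number 9.5 percentage points lower from compound 2 to compound 3 (within the scatter), is within the scatter, while the fall a number 56 percentage points lower from compound 1 to compound 3 (beyond the scatter) is large. Compound 4 `Nc1ccccc1NC(=O)c1ccc(CSC(=S)N2CCN(c3ncccn3)CC2)cc1` brings one change: pyrimidin-2-yl in place of 4-methylphenyl on an amine nitrogen in a ring. Among the measured compounds shown here, the steps that bear on it are a number 46.5 percentage points lower from compound 1 to compound 2 (beyond the scatter) and a number 56 percentage points lower from compound 1 to compound 3 (beyond the scatter), both large falls when a six-membered aromatic ring is the group on the amine nitrogen in a ring, and a number 9.5 percentage points lower from compound 2 to compound 3 (within the scatter), which shows that exchanging one substituent on such a ring moves little. Compound 4 again carries a six-membered aromatic ring on that nitrogen, so in this assay the expected step is a number 6.6 percentage points higher from compound 3 to compound 4 (within the scatter), within the scatter. Compound 4 is therefore estimated at 33%, with a range from 14% to 60%.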

Compound 4, a percentage reported as inhibition, at one concentration (the size of the read-out at that concentration, not a potency): 67.9%
The estimate for compound 4 lay 34.9 percentage points below the measured number; the measured number lies above the stated range.
By their numbers in this assay, from the lowest: compounds 3 and 2 (each within the scatter of the next); then compound 4; then compound 1.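

In this assay, an aromatic ring on the amine nitrogen in a ring does not by itself bring the low numbers of compound 2 and compound 3: with pyrimidin-2-yl, whose ring holds hetero atoms and hydrogen-bond acceptors that the 4-methylphenyl group lacks, the number moves a number 41.5 percentage points higher from compound 3 to compound 4 (beyond the scatter), and it moves a number 32 percentage points higher from compound 2 to compound 4 (beyond the scatter). The two compounds with a nitrogen in the aromatic ring of this group now hold the two highest numbers, yet (pyridin-2-yl)methyl keeps a lead, the change to pyrimidin-2-yl giving a number 14.5 percentage points lower from compound 1 to compound 4 (beyond the scatter). No measurement given here explains the rise.

The compounds shown do not separate the effect of the ring nitrogens from that of the methylene link, as neither a pyridin-2-yl group placed directly on the nitrogen nor a (pyrimidin-2-yl)methyl group appears among them. Nor do they show how an unsubstituted phenyl or a benzyl group would compare.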